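Aryl in Place of Alkyl on a Ring Nitrogen

The source may report more compounds than this note shows. Statements on the series, on what has been measured and on what is new or still open speak of the compounds shown alone.

Of the compounds shown here, two have been measured in an in vitro functional assay on cells for antagonist activity at metabotropic glutamate receptor 1 (Homo sapiens), read by FLIPR and calcium flux; a lower number here means a stronger inhibitor, a higher number a weaker inhibitor. Compound 1 `Cc1nc2c(cnn2-c2ccccc2)c(=O)n1N1CCCCCC1` gives 240 nM. Compound 2 `Cc1nc2c(cnn2CC2CCCCC2)c(=O)n1-c1ccc(Cl)cc1` gives > 100000 nM, which is a limit of the assay and not a number. Compound 2 thus stands at the limit of > 100000 nM in this assay, at which 1 of the 2 values shown sits, the weaker end of what has been seen. Compound 3 `Cc1cccc(-n2ncc3c(=O)n(-c4ccc(Cl)cc4)c(C)nc32)c1` differs from compound 2 by 3-methylphenyl in place of cyclohexylmethyl on an aromatic nitrogen. Within the data shown here, no measured pair isolates this change, so the expected step is uncertain; compound 1 carries an aromatic ring on the same nitrogen and is active, but it also differs elsewhere. The step of an at least 5.0-fold lower number from compound 2 to compound 3 (0.69 log units; beyond the scatter) is expected to be a gain beyond the scatter. Compound 3 is estimated at 20000 nM, with a range of 2000 nM to 100000 nM.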

Compound 3, half-maximal inhibitory concentration: 180 nM
The estimate for compound 3 lay 110-fold (2.05 log units) above the measured number; measured number outside the range, below it.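

In this assay, 3-methylphenyl in place of cyclohexylmethyl on this aromatic nitrogen gives an at least 550-fold lower number from compound 2 to compound 3 (2.74 log units; beyond the scatter). The two groups match in size, each with 7 heavy atoms, all carbon, and differ in that one ring is aromatic and the other is not, so this nitrogen responds strongly to that swap. Compound 2 sits at a limit of the assay and not at a number: the limit of > 100000 nM in this assay, at which 1 of the 3 values shown sits.

Going by these compounds, whether the methyl of the 3-methylphenyl group contributes stays open. So does how a pyridine ring or a benzyl group would fare on this nitrogen.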